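Swapping the Aryl Piperazine Cap on a Benzamide Dithiocarbamate

The source may report more compounds than this note shows. Statements on the series, on what has been measured and on what is new or still open speak of the compounds shown alone.

Three compounds sharing one core were examined in a functional assay on A-375 cells (Homo sapiens) for antiproliferative activity, read by CCK-8 assay, with a stated time of 72 h, tested at 2 uM; on this read-out lower numbers stand for a weaker effect and higher numbers for a stronger effect at the one concentration tested. Compound 1 `Nc1ccccc1NC(=O)c1ccc(CSC(=S)N2CCN(C(c3ccccc3)c3ccccc3)CC2)cc1` gives 8.7% in this assay. Compound 2 `Nc1ccccc1NC(=O)c1ccc(CSC(=S)N2CCN(c3ccc(Cl)cc3)CC2)cc1` gives 32.2% in this assay. Compound 3 `Nc1ccccc1NC(=O)c1ccc(CSC(=S)N2CCc3ccccc32)cc1` gives 25.7% in this assay. On these numbers compound 2 stands highest of the three, yet its gap to compound 3 lies within the usual scatter, so the two cannot be ordered; only its gap to compound 1 lies beyond the scatter.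

The next compound, compound 4 `Nc1ccccc1NC(=O)c1ccc(CSC(=S)N2CCN(c3cccnc3)CC2)cc1`, differs from compound 2 in one place: pyridin-3-yl in place of 4-chlorophenyl on an amine nitrogen in a ring. Within the data shown here, no measured pair in this set shows what such a change does, so the direction is open. The account expects a modest decrease, if any, not clearly beyond the scatter, and the step from compound 2 to compound 4 is expected to be a number 10.2 percentage points lower from compound 2 to compound 4 (beyond the scatter) in this assay. Compound 4 is therefore expected to give about 22% in this assay, with a plausible range from 8% to 38%.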

Compound 4, a percentage reported as inhibition, at one concentration (the size of the read-out at that concentration, not a potency): 40.5%
Beside the measured number, compound 4's estimate is 18.5 percentage points below it; measured number outside the range, above it.
By their numbers in this assay, from the lowest: compound 1; then compounds 3, 2 and 4 (each within the scatter of the next, the first and the last beyond it).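

In this assay, pyridin-3-yl in place of 4-chlorophenyl on the amine nitrogen in a ring gives a number 8.3 percentage points higher from compound 2 to compound 4 (within the scatter), so the two compounds cannot be ordered. Among these compounds, this is the first pair in the set that differs in one place, and it shows that exchanging a carbon-only aromatic ring bearing chlorine for an aromatic ring with one hetero atom and one hydrogen-bond acceptor leaves the read-out within the scatter at this position. Nothing measured here accounts for this outcome.

The pair changes the ring atom and removes the chlorine together, so the contribution of each stays unresolved. A plain phenyl group or a pyrimidine ring on the same nitrogen could help to separate them, and the single tested concentration leaves potency open.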